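The source may report more compounds than this note shows. Statements on the series, on what has been measured and on what is new or still open speak of the compounds shown alone.

Measured so far in a functional assay on L1210 cells (Mus musculus), with a stated time of 1 days; on this read-out lower numbers stand for lower potency and higher numbers for higher potency (the scale is a negative logarithm):
compound 1 `CC1=C(N2CC2)C(=O)C(CC(C)OC(N)=O)=C(N2CC2)C1=O` gives 5.86
compound 2 `CCCC1=C(N2CC2)C(=O)C(CCC)=C(N2CC2)C1=O` gives 4.32
compound 3 `CC1=C(N2CC2)C(=O)C(C(C)COC(N)=O)=C(N2CC2)C1=O` gives 5.93

Compound 3 holds the highest of the three numbers, though compound 1 sits within the scatter of it; only compound 2 lies clearly lower, beyond the scatter. Compound 4 `CCC(OC)C1=C(N2CC2)C(=O)C(C)=C(N2CC2)C1=O` differs from compound 3 by a group of 5 heavy atoms (4 carbon, 1 oxygen; no ring) in place of a group of 7 heavy atoms (4 carbon, 1 nitrogen, 2 oxygen; no ring), on a double-bonded ring carbon. For the measured compounds named here, the single measured step, a number 0.07 log units higher from compound 1 to compound 3 (within the scatter), exchanged one group of 7 heavy atoms for another of the same make-up and changed nothing beyond the scatter, so it says little about removing that group altogether. Compound 2, which carries plain chains on both sides, is the only hint, and its number is far lower. Compound 4 is therefore expected near 5, within 4.3 to 5.7. The expected step is a number 0.93 log units lower from compound 3 to compound 4 (beyond the scatter).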

Compound 4, logarithm of the reciprocal of the active concentration, log(1/C): 5.26
Compound 4: middle estimate off by 0.26 log units, on the low side, within the range that was stated.
By their numbers in this assay, from the lowest: compound 2; then compound 4; then compounds 1 and 3 (each within the scatter of the next).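

Replacing the chain on this double-bonded ring carbon with 1-methoxypropyl lowers the number in this assay by a modest but real amount (a number 0.67 log units lower from compound 3 to compound 4 (beyond the scatter)) and (a number 0.60 log units lower from compound 1 to compound 4 (beyond the scatter)). For the compounds shown here, the earlier exchange between two chains of identical make-up moved nothing beyond the scatter, so this is the first sign that the position responds to the nature of its group, here a change that drops the hydrogen-bond donor. No measurement on hand explains the loss. As far as these compounds go, whether a hydroxyethyl or an aminoethyl chain on this carbon would stay level with compound 3 remains open.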